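This account rests on a few compounds, and the source may have more. Where it says the series, first, only, none or still open, it means among the compounds named here.

Measured compounds, read-out in an assay on NIH3T3 cells with Urotensin-2 receptor (Homo sapiens) as the target; on this read-out higher numbers stand for an effect only at larger amounts of compound and lower numbers for an effect already at smaller amounts:
- compound 1 `Cc1c(Cl)cccc1C(=O)OC(CCN(C)C)c1ccc(Cl)cc1` gives 1120 nM
- compound 2 `Cc1cc(Br)ccc1C(=O)OC(CCN(C)C)c1ccc(Cl)cc1` gives 1070 nM
- compound 3 `Cc1ccccc1C(=O)NC(CCN(C)C)c1ccc(Cl)cc1` gives 3550 nM

Compound 3 stands at the highest of the three numbers; compound 1 and compound 2 both lie beyond the scatter below it. Among the compounds with values here, the only step available is a 1.0-fold lower number from compound 1 to compound 2 (0.02 log units; within the scatter), a change of the aryl group on the carbonyl carbon that left the number essentially where it was.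

Compound 4 `CN(C)CCC(NC(=O)NCc1ccccc1)c1ccc(Cl)cc1` is not yet measured in this assay. It differs from compound 3 by benzylamino in place of 2-methylphenyl on a carbonyl carbon. Within the data shown here, no measured pair shows an aryl group on the carbonyl carbon giving way to a benzylamino group, so the step from compound 1 to compound 2 bears on it only loosely: it shows that a change at this carbonyl carbon can leave this assay unmoved, but that change kept an aryl group in place. The expectation for compound 4 is therefore taken from compound 3, with wide uncertainty in either direction, and is expected as a 1.0-fold lower number from compound 3 to compound 4 (0.01 log units; within the scatter). The value expected for compound 4 is 3500 nM, within 1000 nM to 12000 nM.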

Compound 4, half-maximal effective concentration: 2000 nM
Compound 4: the middle estimate sits 1.8-fold (0.24 log units) above what was measured, and the stated range covers the measured number.
By their numbers in this assay, from the lowest: compounds 2, 1, 4 and 3 (each within the scatter of the next, the first and the last beyond it).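

In this assay, benzylamino in place of 2-methylphenyl on the carbonyl carbon gives a 1.8-fold lower number from compound 3 to compound 4 (0.25 log units; within the scatter) and is the only step shown that removes the aryl group from this carbon. The entering group brings a nitrogen and a hydrogen-bond donor that 2-methylphenyl lacks, yet the number stays within the scatter, so this position accepts a change in the atom bound to the carbonyl carbon, not only in the substituents on an aryl group. No evidence on the reason for this result is available.

As far as these compounds go, whether the benzylamino ring can carry chloro or bromo, as the aryl groups of compound 1 and compound 2 do, remains open, as does a longer chain such as phenethylamino. Also open, from the compounds shown here alone, is whether dimethylamino or a carboxylic acid at this place would keep the number in this range.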